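From 4-methoxyphenyl to 2-methoxyphenyl

The source may report more compounds than this note shows. Statements on the series, on what has been measured and on what is new or still open speak of the compounds shown alone.

Compound 1 `Brc1cccc(Cc2nnc(Cn3nnc4ccccc43)o2)c1` gives 269000 nM
Compound 2 `Brc1ccc(Cc2nnc(Cn3nnc4ccccc43)o2)cc1` gives 277000 nM
Compound 3 `COc1ccc(Cc2nnc(Cn3nnc4ccccc43)o2)cc1` gives 251000 nM

All three values come from a functional assay on MCF7 cells (Homo sapiens) for antiproliferative activity, read by MTT assay, with a stated time of 24 h (on this read-out lower numbers stand for stronger inhibition and higher numbers for weaker inhibition), and lie close together. Compound 3 stands level with the other two, as the step of a 1.1-fold lower number from compound 1 to compound 3 (0.03 log units; within the scatter) and the step of a 1.1-fold lower number from compound 2 to compound 3 (0.04 log units; within the scatter) both show.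

The next compound is compound 4 `COc1ccccc1Cc1nnc(Cn2nnc3ccccc32)o1`, which keeps the shared core of compound 3. The difference is 2-methoxyphenyl in place of 4-methoxyphenyl on a saturated chain carbon bound to an aromatic carbon, with 2-methoxyphenyl in place of 4-methoxyphenyl on a saturated chain carbon bound to an aromatic carbon.

Among the compounds with values here, no measured compound carries the 2-methoxyphenyl group, so the evidence is indirect. The nearest parallel is the exchange of 3-bromophenyl for 4-bromophenyl, the step of a 1.0-fold higher number from compound 1 to compound 2 (0.01 log units; within the scatter), which also alters only where the substituent sits. The exchange of bromo for methoxy, the step of a 1.1-fold lower number from compound 2 to compound 3 (0.04 log units; within the scatter), was just as small. On the strength of these two steps, no shift beyond the scatter is expected in this assay, and no direction can be favoured.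

The estimated step is a 1.0-fold lower number from compound 3 to compound 4 (0.00 log units; within the scatter) and nothing larger is expected.

For compound 4 the estimated value is 250000 nM, with an expected range from 130000 nM to 480000 nM.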

Compound 4, half-maximal inhibitory concentration: 15000 nM
Compound 4: the middle estimate sits 17-fold (1.22 log units) above what was measured, and the stated range ends above it.
By their numbers in this assay, from the lowest: compound 4; then compounds 3, 1 and 2 (each within the scatter of the next).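

With the atoms unchanged and only their joining altered, 2-methoxyphenyl in place of 4-methoxyphenyl on a saturated chain carbon bound to an aromatic carbon gives a 17-fold lower number from compound 3 to compound 4 (1.22 log units; beyond the scatter) in this assay and so shows that this position can respond strongly to where the substituent sits, which the exchange of 3-bromophenyl for 4-bromophenyl, at a 1.0-fold higher number from compound 1 to compound 2 (0.01 log units; within the scatter), had not revealed. Compound 4 also separates clearly from both bromo compounds, with an 18-fold lower number from compound 2 to compound 4 (1.27 log units; beyond the scatter) and with an 18-fold lower number from compound 1 to compound 4 (1.25 log units; beyond the scatter), while the three earlier compounds remain within the scatter of one another. The flat picture given by those three compounds therefore does not hold for the whole of this position, and compound 4 is the one exception among the four. Nothing at hand bears on why the 2-methoxyphenyl group departs from the others.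

The compounds shown leave open whether the gain belongs to the methoxy group itself or would survive with bromo, hydroxy or an amine in its place within the 2-methoxyphenyl group. They also leave open how 3-methoxyphenyl would compare, which would show whether compound 4 stands alone among the methoxy isomers.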